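The compounds below may be only part of what the source reports. "The series", "measured", "known", "first", "only" and "open" are said of these compounds alone.

Compound 1 `Cc1cc(-c2ccccc2)cn2c(CSCCc3ccccc3)cnc12` carries an unsubstituted phenyl on the shared core, and in an ADME assay on HEL cells (Homo sapiens) for cytotoxicity, with a stated time of 3 days (a higher number here means that more compound is tolerated, a lower number that less compound is tolerated), compound 1 gives 20 ug/mL. Compound 2 `Cc1cc(-c2ccc(O)cc2)cn2c(CSCCc3ccccc3)cnc12` has hydroxy in place of hydrogen on an aromatic carbon of that phenyl. In this assay compound 2 reaches only a limit of the assay, >= 100 ug/mL, not a number. The step of an at least 5.0-fold higher number from compound 1 to compound 2 (0.69 log units; beyond the scatter) is the one move beyond the scatter among the three measured compounds. Compound 3 `COc1cccc(-c2cc(C)c3ncc(CSCCc4ccccc4)n3c2)c1` carries methoxy in place of hydrogen instead; in this assay compound 3 gives 20 ug/mL, level with compound 1 at the digits shown, as no change at the digits printed from compound 1 to compound 3 (within the scatter) records, while its distance from compound 2 is an at least 5.0-fold lower number from compound 2 to compound 3 (0.69 log units; beyond the scatter). Compound 4 `Cc1cc(-c2ccsc2)cn2c(CSCCc3ccccc3)cnc12` has not yet been measured; it differs from compound 3 by thiophen-3-yl in place of 3-methoxyphenyl on an aromatic carbon. Both measured steps starting from compound 1 bear on this change: the methoxy variant left the number unchanged, whereas only the hydroxy variant sits at the limit of >= 100 ug/mL in this assay, at which 1 of the 3 values shown sits. The thiophen-3-yl carries no hydroxy, and the expectation is therefore no step beyond the scatter. Compound 4 is expected to give about 20 ug/mL, within 10 ug/mL to 50 ug/mL. This expectation corresponds to a step of no change at the digits printed from compound 3 to compound 4 (within the scatter).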

Compound 4, minimum cytotoxic concentration: >= 4 ug/mL
Compound 4: a limit, no number; the forecaster's own chance of this, stated with the estimate: 20%; the middle value lies beyond the limit too.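

In this assay compound 4 gives only a limit, >= 4 ug/mL, not a number, so its steps from compound 1, compound 2 and compound 3 cannot be read. The compounds shown leave open whether thiophen-3-yl in place of phenyl or 3-methoxyphenyl changes the tolerated concentration at all, or by how much.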